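The source may hold more compounds than are shown below. What is called first, only, known or untested is meant among the compounds shown, and "the series" means these compounds.

The series shares a core in which a sulfonyl sulfur carries an aryl group and a sulfonamide nitrogen in a ring. Compound 1, `CC1CCN(C2CCN(S(=O)(=O)c3ccc(F)cc3F)CC2)CC1`, is measured in a functional assay on DLD-1 cells (Homo sapiens) for antiproliferative activity, read by CellTiter-Glo, with a stated time of 72 h (a higher number here means a weaker inhibitor, a lower number a stronger inhibitor), where compound 1 gives 102 nM. That is the highest of the two numbers recorded; the nearest is compound 3, `COc1ccc(Br)cc1S(=O)(=O)N1CCC(N2CCC(C)CC2)CC1`, which in this assay gives 2 nM, a gap beyond the scatter. Compound 2, `COc1cc(C)ccc1S(=O)(=O)N1CCC(N2CCC(C)CC2)CC1`, sits at the limit of > 5000 nM in this assay, at which 1 of the 3 values shown sits, so for compound 2 the value > 5000 nM is a limit and not a number. Compound 4, `CC1CCN(C2CCN(S(=O)(=O)c3ccccc3Br)CC2)CC1`, has not yet been measured. It differs from compound 1 in one place: 2-bromophenyl in place of 2,4-difluorophenyl on a sulfonyl sulfur. Going by the values given here, no measured pair in this set isolates that change, since compound 2 and compound 3 each carry a different aryl group from compound 1 and from one another, and the two numbers that exist lie far apart. Without a measured step to lean on, compound 4 is expected to remain near compound 1 or become somewhat stronger, and the step this would mean is a 1.7-fold lower number from compound 1 to compound 4 (0.23 log units; within the scatter). Compound 4 is therefore estimated at 60 nM in this assay, within a range from 10 nM to 400 nM.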

Compound 4, half-maximal inhibitory concentration: 3 nM
For compound 4 the middle estimate is 20-fold (1.30 log units) above the measured one; the measured number lies below the stated range.
By their numbers in this assay, from the lowest: compounds 3 and 4 (each within the scatter of the next); then compound 1. At a limit, above all of these: compound 2.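

In this assay, replacing 2,4-difluorophenyl with 2-bromophenyl on a sulfonyl sulfur gives a 34-fold lower number from compound 1 to compound 4 (1.53 log units; beyond the scatter), a large step from a single change with the rest of the core of compound 1 held fixed. This is the only measured pair shown that isolates a change at this place, and it establishes that the choice of aryl group on the sulfonyl sulfur can by itself move the number far beyond the scatter, which compound 2 and compound 3 could not show because each differs from compound 1 in more than one respect. No measurement shown gives a reason for the size of this step.

The step exchanges one whole aryl group for another, so the compounds shown do not separate the gain of the bromine from the loss of the two fluorines. Going by these compounds alone, it also remains open how an unsubstituted phenyl group or a chlorophenyl group on the same sulfonyl sulfur would compare with compound 1 and compound 4, and the single pair shows nothing about other groups at this place.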